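Second stereoinversion in the allyl-phenol ether series

This account rests on a few compounds, and the source may have more. Where it says the series, first, only, none or still open, it means among the compounds named here.

Compound 3 `C=CCc1cc(OC)c(O[C@@H](C)[C@@H](OCC)c2ccc(O)c(OC)c2)c(OC)c1` gives 87 nM in an assay on HEK293 cells for agonist activity at transient receptor potential cation channel subfamily M member 8 (Homo sapiens), read by fluorescence and calcium flux, with a stated time of 5 min (on this read-out lower numbers stand for an effect already at smaller amounts and higher numbers for an effect only at larger amounts of compound), the second highest of the three numbers. Compound 2 `C=CCc1cc(OC)c(OC(C)C(OCCCCCCCCCC)c2ccc(O)c(OC)c2)c(OC)c1` gives 66 nM in this assay, within the scatter of compound 3. Compound 1 `C=CCc1cc(OC)c(O[C@H](C)[C@@H](OCC)c2ccc(O)c(OC)c2)c(OC)c1` gives 1150 nM in this assay. Compound 4 `C=CCc1cc(OC)c(O[C@@H](C)[C@H](OCC)c2ccc(O)c(OC)c2)c(OC)c1` is not yet measured; (the two compounds have the same atoms and bonds and differ only in configuration as drawn: 1 of 2 stereo elements differ; a stereocentre at a saturated chain carbon is drawn S in compound 3 and R in compound 4). Going by the values given here, the only measured step of the same kind is a 13-fold lower number from compound 1 to compound 3 (1.12 log units; beyond the scatter), which rests on (the fact that compounds 1 and 3 differ only in the configuration as drawn). A single inversion thus moved the number far; the present inversion sits at the other centre, and its direction is not fixed by these data. A step toward a higher number of moderate size is expected, a 3.4-fold higher number from compound 3 to compound 4 (0.54 log units; beyond the scatter). Compound 4 is estimated at 300 nM, with a range from 50 nM to 2000 nM.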

Compound 4, half-maximal effective concentration: 1130 nM
For compound 4 the middle estimate is 3.8-fold (0.58 log units) below the measured one; the measured number falls inside the stated range.
By their numbers in this assay, from the lowest: compounds 2 and 3 (each within the scatter of the next); then compounds 4 and 1 (each within the scatter of the next).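

Inverting the second stereocentre matters as much in kind as inverting the first: a 13-fold higher number from compound 3 to compound 4 (1.11 log units; beyond the scatter), and the earlier step at the other centre was also large: a 13-fold lower number from compound 1 to compound 3 (1.12 log units; beyond the scatter). The mirror-image pair shows no separation: a 1.0-fold lower number from compound 1 to compound 4 (0.01 log units; within the scatter). Among the three compounds with drawn configuration, the low number therefore belongs to compound 3 alone.

Still open, on these data alone, is how far this configuration dependence carries over to the longer ether chain of compound 2, which is drawn without defined stereocentres. Also open, as far as these compounds go, is whether an amine or a carboxylic acid in place of that chain would keep the number of compound 3.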